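This account rests on a few compounds, and the source may have more. Where it says the series, first, only, none or still open, it means among the compounds named here.

Compound 1 `O=C(Nc1ccc(-c2ccccc2)cc1)C1CCCN(Cc2ccc(F)c(F)c2)C1`: 2580 nM
Compound 2 `O=C(Nc1ccc(-c2nccs2)cc1)C1CCCN(Cc2ccc(F)c(F)c2)C1`: 240 nM
Compound 3 `O=C(Nc1ccc(-c2c[nH]cn2)cc1)C1CCCN(Cc2ccc(F)c(F)c2)C1`: > 20000 nM (a limit)

All three entries come from a functional assay on A-375 cells (Homo sapiens) for antiproliferative activity; on this read-out higher numbers stand for weaker inhibition and lower numbers for stronger inhibition. Compound 3 is known only by a limit, and it sits at the limit of > 20000 nM in this assay, at which 1 of the 3 values shown sits.

Compound 4 `O=C(Nc1ccc(-c2ncc[nH]2)cc1)C1CCCN(Cc2ccc(F)c(F)c2)C1` has the same atoms as compound 3, joined differently: 1H-imidazol-2-yl in place of 1H-imidazol-4-yl on an aromatic carbon. The change is 1H-imidazol-2-yl in place of 1H-imidazol-4-yl on an aromatic carbon, para to a large group.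

Among the compounds with values here, no measured pair makes this exact exchange. The nearest evidence comes from the other group exchanges at this place. These are an 11-fold lower number from compound 1 to compound 2 (1.03 log units; beyond the scatter), an at least 7.7-fold higher number from compound 1 to compound 3 (0.88 log units; beyond the scatter) and an at least 83-fold higher number from compound 2 to compound 3 (1.92 log units; beyond the scatter). All three steps lie beyond the scatter, so the read-out responds strongly to the group here. The entering 1H-imidazol-2-yl shares the 2-yl ending of the 1,3-thiazol-2-yl in compound 2 at 240 nM, and this is the basis for expecting a lower number for compound 4. A large step to a lower number is therefore expected in this assay, though a second limit remains possible. The expected change is an at least 8.0-fold lower number from compound 3 to compound 4 (0.90 log units; beyond the scatter).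

For compound 4 the estimated value is 2500 nM, with an expected range of 300 nM to 20000 nM.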

Compound 4, half-maximal inhibitory concentration: 19000 nM
The estimate for compound 4 lay 7.6-fold (0.88 log units) below the measured number; the range from low to high includes it.
By their numbers in this assay, from the lowest: compound 2; then compound 1; then compound 4. At a limit, above all of these: compound 3.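

In this assay, the shared 2-yl ending does not carry the thiazole level over to the imidazole, with a 79-fold higher number from compound 2 to compound 4 (1.90 log units; beyond the scatter), and the 1H-imidazol-2-yl group also falls on the weak side of phenyl, with a 7.4-fold higher number from compound 1 to compound 4 (0.87 log units; beyond the scatter). The exchange of one imidazole isomer for the other gives an at least 1.0-fold lower number from compound 3 to compound 4 (0.02 log units; that floor lies within the scatter), so on this read-out the attachment point of the imidazole shows no separation that can be claimed, and both isomers stay far from the thiazole of compound 2. Compound 3 is known only as a limit and not as a number, which leaves that step a floor: the limit of > 20000 nM in this assay, at which 1 of the 4 values shown sits.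

Still open, on these data alone, is whether the weak numbers go with the hydrogen-bearing ring nitrogen shared by the two imidazoles, which 1-methyl-1H-imidazol-2-yl or 1,3-oxazol-2-yl at the same place would test. Also open, as far as these compounds go, is whether the thiazole result depends on its attachment point, a question for 1,3-thiazol-4-yl and 1,3-thiazol-5-yl on the same core.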